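The source may report more compounds than this note shows. Statements on the series, on what has been measured and on what is new or still open speak of the compounds shown alone.

Three compounds carrying the same shared core were examined in an ADME assay on Vero cells (Chlorocebus sabaeus) for cytotoxicity, read by neutral red uptake, with a stated time of 72 h; on this read-out higher numbers stand for weaker inhibition and lower numbers for stronger inhibition. Compound 1 `Clc1ccc(Nc2ccnc(NCCNc3ccnc4cc(Cl)ccc34)n2)cc1` gives 15800 nM in this assay. Compound 2 `Clc1ccc(Nc2ccnc(NCCCNc3ccnc4cc(Cl)ccc34)n2)cc1` gives 13400 nM. Compound 3 `Clc1ccc2c(NCCCCNc3nccc(Nc4ccccc4)n3)ccnc2c1` gives 14300 nM, a number that sits within the usual scatter of both compound 2 and compound 1, so that no one of the three can be told apart from the others on this read-out; the three numbers form a single tight cluster.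

Compound 4 `COc1ccc(Nc2ccnc(NCCCCNc3ccnc4cc(Cl)ccc34)n2)cc1` has not yet been measured in this assay. It differs from compound 3 in one place: methoxy in place of hydrogen on an aromatic carbon, that is, a methoxy group in place of a hydrogen on an aromatic carbon, para to a large group, so that the anilino end of compound 3 becomes a (4-methoxyphenyl)amino end. For the measured compounds named here, no pair of measured compounds shows the effect of such a change, so no step of this kind is known from the data. Given that the three measured compounds lie within the scatter of one another, the step expected from compound 3 to compound 4 is a 1.0-fold lower number from compound 3 to compound 4 (0.01 log units; within the scatter), with no direction beyond the scatter. Compound 4 is therefore estimated at 14000 nM, with a likely range from 7000 nM to 28000 nM.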

Compound 4, half-maximal inhibitory concentration: 11100 nM
Beside the measured number, compound 4's estimate is 1.3-fold (0.10 log units) above it; the measured number falls inside the stated range.
By their numbers in this assay, from the lowest: compounds 4, 2, 3 and 1 (each within the scatter of the next).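

For the compounds shown here, compound 3 and compound 4 form the first pair in this set that differs in one place, so they give the first direct reading of a change on this aromatic carbon, para to a large group. In this assay, methoxy in place of hydrogen gives a 1.3-fold lower number from compound 3 to compound 4 (0.11 log units; within the scatter), so the two compounds cannot be told apart on this read-out, and a group of 2 heavy atoms with 1 hydrogen-bond acceptor can stand at this position without a change that is visible beyond the scatter. No measurement is at hand that would explain this result.

Going by these compounds, whether this position stays as undemanding with other groups, such as an amine, a carboxylic acid or a trifluoromethyl group, remains open, because this one step speaks only for methoxy. On these data alone, it is also open whether the same change would read the same way on a compound with a longer chain, and whether a step beyond the scatter can be found at this position at all.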